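A few compounds are considered here, and "the series" means these few. Any claim that something is new, unique, unknown or untested is made for them only; others in the source may bear on it.

Measured so far:
Compound 1 `C=C1C[C@]23C[C@@]1(O)CC[C@H]2c1ccc(OS(=O)(=O)c2ccc(C)cc2)c(C)c1[C@@H]3Cn1cc(-c2ccc(C)cc2)nn1`. In a functional assay on SMMC-7721 cells (Homo sapiens) for cytotoxicity, read by MTT assay, with a stated time of 4 days (on this read-out lower numbers stand for stronger inhibition and higher numbers for weaker inhibition), compound 1 reaches only the limit of the assay, > 20000 nM.
Compound 2 `C=C1C(=O)[C@]23C[C@@]1(O)CC[C@H]2c1ccc(O)c(C)c1[C@@H]3Cn1cc(-c2ccc(Br)cc2)nn1`. In this assay compound 2 gives 1300 nM.
Compound 3 `C=C1C(=O)[C@]23C[C@@]1(O)CC[C@H]2c1ccc(OS(=O)(=O)c2ccc(C)cc2)c(C)c1[C@@H]3Cn1cc(-c2ccc(Br)cc2)nn1`. In this assay compound 3 gives 4320 nM.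

Compound 2 holds the lowest of the two numbers in hand. Its nearest neighbour is compound 3, reached by a step of a 3.3-fold higher number from compound 2 to compound 3 (0.52 log units; beyond the scatter) when (4-methylphenyl)sulfonyl replaces hydrogen on an oxygen of the aromatic ring. Within the data shown here, compound 1 is the one value sitting at the limit of > 20000 nM in this assay, at which 1 of the 3 values shown sits, so it contributes no number.

Compound 4 `C=C1C(=O)[C@]23C[C@@]1(O)CC[C@H]2c1ccc(O)c(C)c1[C@@H]3Cn1cc(-c2ccc(OC)cc2)nn1` differs from compound 2 at another place altogether: methoxy in place of bromo on an aromatic carbon. Among the measured compounds shown here, no measured step touches this part of the molecule. For the measured compounds named here, the one step in hand, from compound 2 to compound 3, concerns the oxygen on the aromatic ring of the shared core, and compound 1 gives only a limit. There is therefore no measured basis for expecting a step beyond the scatter in either direction in this assay, and the estimate simply stays near compound 2. Compound 4 is expected to give about 1700 nM, with a likely range from 600 nM to 5000 nM. That estimate amounts to an expected step of a 1.3-fold higher number from compound 2 to compound 4 (0.12 log units; within the scatter).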

Compound 4, half-maximal inhibitory concentration: 860 nM
Estimate against measurement, compound 4: 2.0-fold (0.30 log units) above; low and high end bracket the measured number.
By their numbers in this assay, from the lowest: compounds 4 and 2 (each within the scatter of the next); then compound 3. At a limit, above all of these: compound 1.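

Until now no readable step touched this position, since compound 1 carries only a limit and differs from the others in more than one place. In this assay, replacing bromo with methoxy on this aromatic carbon, para to a large group, gives a 1.5-fold lower number from compound 2 to compound 4 (0.18 log units; within the scatter), so 4-bromophenyl and 4-methoxyphenyl cannot be told apart here. Among these compounds, the free hydroxyl on the aromatic ring of the shared core stays in place in both compounds, which keeps this comparison to the one change, and nothing in hand gives a reason for the two groups reading alike.

Going by these compounds, it remains open how an amine, a carboxylic acid or a longer chain at this position would read. On these data alone, it is also open whether the same exchange would read alike with (4-methylphenyl)sulfonyl on the oxygen, as in compound 3.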